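This account rests on a few compounds, and the source may have more. Where it says the series, first, only, none or still open, it means among the compounds named here.

Measured so far:
compound 1, `O=c1[nH]c(=O)n(C2COC(CO)C(O)C2)cc1C(F)(F)F`, gives > 400 ug/mL in a functional assay on E6SM cells (Homo sapiens) for cytotoxicity, read by microscopy; a lower number here means that less compound is tolerated, a higher number that more compound is tolerated; this is a limit of the assay, not a number.
compound 2, `C#Cc1cn(C2COC(CO)C(O)C2)c(=O)[nH]c1=O`, gives 400 ug/mL in this assay.
compound 3, `CC#Cc1cn(C2COC(CO)C(O)C2)c(=O)[nH]c1=O`, gives > 400 ug/mL in this assay; again only a limit.

Compound 3 thus stands at the ceiling reached by two of the three values, (the limit of > 400 ug/mL in this assay, at which 2 of the 3 values shown sit); compound 2 alone returned a number, and it sits at the same concentration. Compound 4, `O=c1[nH]c(=O)n(C2COC(CO)C(O)C2)cc1-c1cccs1`, alters compound 3 by thiophen-2-yl in place of prop-1-yn-1-yl on an aromatic carbon. Within the data shown here, no measured step exchanges a chain for a ring: a step that the two limits leave unreadable from compound 1 to compound 3 and a number no lower from compound 2 to compound 3 (the limit leaves the size open) end at a limit, and a number no higher from compound 1 to compound 2 (the limit leaves the size open) is equally unreadable. Nothing here points to a direction beyond the scatter. The step of an at least 1.3-fold lower number from compound 3 to compound 4 (0.12 log units; that floor lies within the scatter) is therefore expected to be small. Compound 4 is expected near 300 ug/mL, within 120 ug/mL to 400 ug/mL, quite possibly again only as a limit.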

Compound 4, minimum cytotoxic concentration: > 400 ug/mL
Compound 4 was reported as a limit; the forecaster's own chance of this, stated with the estimate: 55%; middle value at least 1.3-fold (0.12 log units) from the limit.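

With thiophen-2-yl, a ring now sits on this aromatic carbon where only trifluoromethyl and the alkynyl chains stood, and the read-out stays at the ceiling of the assay: the limit of > 400 ug/mL in this assay, at which 3 of the 4 values shown sit.

Among these compounds, of the new steps, only a number no lower from compound 2 to compound 4 (the limit leaves the size open) has a direction, and no step to compound 4 has a readable size. A ring in place of a chain therefore shows no measurable change here.

Open, as far as these compounds go, is how an amine, a carboxylic acid or a longer alkyl chain on this carbon would read in this assay, and whether any group here gives a number clearly under the ceiling.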